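Swapping cyano for fluoro on an aromatic ring

The source may report more compounds than this note shows. Statements on the series, on what has been measured and on what is new or still open speak of the compounds shown alone.

In an ADME assay on MT4 cells (Homo sapiens) for cytotoxicity, read by MTT assay, with a stated time of 5 days (on this read-out lower numbers stand for higher toxicity in this test and higher numbers for lower toxicity in this test), compound 1 `Cc1cc(C#N)cc(C)c1Oc1nc(NC2CCC(NC(=O)c3ccccc3)CC2)nc2ccsc12` gives 3930 nM, compound 2 `Cc1cc(C#N)cc(C)c1Oc1nc(NC2CCC(NS(=O)(=O)c3ccc(C#N)cc3)CC2)nc2ccsc12` gives 9290 nM and compound 3 `Cc1cc(C#N)cc(C)c1Oc1nc(NC2CCC(NS(=O)(=O)c3ccc(Br)cc3)CC2)nc2ccsc12` gives 5860 nM. Within the data shown here, compound 2 is clearly separated from only one of these two neighbours. The measured change from the benzoyl group to the (4-cyanophenyl)sulfonyl group is a 2.4-fold higher number from compound 1 to compound 2 (0.37 log units; beyond the scatter), whereas the change from cyano to bromo is a 1.6-fold lower number from compound 2 to compound 3 (0.20 log units; within the scatter).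

Compound 4 `Cc1cc(C#N)cc(C)c1Oc1nc(NC2CCC(NS(=O)(=O)c3ccc(F)cc3)CC2)nc2ccsc12` keeps all of compound 2 except one small group: fluoro in place of cyano on an aromatic carbon. Put simply, fluoro takes the place of cyano on an aromatic carbon, para to a large group.

The cyano-to-bromo swap already described is the closest guide, since it alters the same place and stays within the scatter. A second measured change points the same way: moving from the benzoyl group to the (4-bromophenyl)sulfonyl group gives a 1.5-fold higher number from compound 1 to compound 3 (0.17 log units; within the scatter). Among the measured compounds shown here, no fluoro compound has yet been measured, so this expectation rests on a single halogen example. The expected change is small, with nothing beyond the scatter: a 1.4-fold lower number from compound 2 to compound 4 (0.16 log units; within the scatter). Compound 4 is estimated at 6500 nM, with an expected range from 3500 nM to 12000 nM.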

Compound 4, half-maximal cytotoxic concentration: 3530 nM
The estimate for compound 4 lay 1.8-fold (0.27 log units) above the measured number; the measured number falls inside the stated range.
By their numbers in this assay, from the lowest: compounds 4, 1, 3 and 2 (each within the scatter of the next, the first and the last beyond it).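

In this assay, the group at this place on the sulfonyl ring can matter: fluoro in place of cyano gives a 2.6-fold lower number from compound 2 to compound 4 (0.42 log units; beyond the scatter) and so clears the scatter, which the earlier swap of cyano for bromo did not. Fluoro and bromo cannot be told apart here, with a 1.7-fold lower number from compound 3 to compound 4 (0.22 log units; within the scatter) as the step between them, and the (4-fluorophenyl)sulfonyl group cannot be told from benzoyl on the amine nitrogen, with a 1.1-fold lower number from compound 1 to compound 4 (0.05 log units; within the scatter) as the step between those two; compound 2 is therefore separated from compound 1 and compound 4, while compound 3 lies within the scatter of all the others. Nothing measured here bears on what lies behind the difference between the cyano and fluoro compounds.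

The compounds shown leave open how other groups at this place would read, such as a methoxy group, an amine, a carboxylic acid or a plain hydrogen. They also leave open whether the same swap of cyano for fluoro would give a similar step on a benzoyl ring, where the sulfonyl link is absent.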